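The compounds below may be only part of what the source reports. "The series", "measured", "known", "first", "only" and "open" are said of these compounds alone.

Three members of this series have been measured in a functional assay (spleen, spleen) for activation, with Mus musculus as the target; a higher number here means that more compound is needed for the effect, a lower number that less compound is needed. Compound 1, `CCCCOc1nc(N)c2[nH]c(=O)n(Cc3ccccc3)c2n1`, gives 0.001 uM in this assay. Compound 2, `CCCNc1nc(N)c2nc(O)n(Cc3ccccc3)c2n1`, gives 0.1 uM in this assay, the higher of the two numbers that are known; its nearest neighbour is compound 1, whose number is far lower, a gap well beyond the usual scatter of repeats. Compound 3, `CSc1nc2c(N)ncnc2n1Cc1ccccc1`, reaches only a limit of this assay, > 10 uM, so that no number is known for it, and this is the limit of > 10 uM in this assay, at which 1 of the 3 values shown sits.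

The compound that remains to be measured is compound 4, `CCCCc1nc(N)c2nc(O)n(Cc3ccccc3)c2n1`. It differs from compound 2 in one place: butyl in place of propylamino on an aromatic carbon. Among the compounds with values here, no step between two measured compounds traces this change, so the expectation rests on the three values alone. Within the data shown here, compound 1 shows that a four-carbon group attached through oxygen at this position goes with a very low number, while compound 2 with propylamino sits much higher; a plain butyl chain at the same carbon has no measured counterpart here. Compound 4 is expected to lie near compound 2, with a step from compound 2 to compound 4 of a 3.0-fold higher number from compound 2 to compound 4 (0.48 log units; beyond the scatter), pointing slightly toward a higher number. The estimate for compound 4 in this assay is therefore 0.3 uM, with a range from 0.03 uM to 3 uM.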

Compound 4, minimum effective concentration: 0.03 uM
Compound 4: middle estimate off by 10-fold (1.00 log units), on the high side; the measured number falls inside the stated range.
By their numbers in this assay, from the lowest: compound 1; then compound 4; then compound 2. At a limit, above all of these: compound 3.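

Butyl in place of propylamino on this aromatic carbon, between two ring nitrogen atoms, gives a 3.3-fold lower number from compound 2 to compound 4 (0.52 log units; beyond the scatter) in this assay, a modest step. Within the data shown here, until now, compound 2 was the only compound with a chain at this carbon that could be set directly against another in a single-place change, so it could not be said whether the chain's nitrogen was needed for the effect. With compound 4 at 0.03 uM, it is clear that the effect survives when propylamino, with its hydrogen-bond donor and acceptor, gives way to butyl, which has neither, and that the number even falls modestly.

The change alters the attached atom and the carbon count of the chain at once, so butylamino, or a propyl chain attached directly through carbon, would be needed to tell these two contributions apart, and a longer chain such as hexyl would show how far the carbon chain can extend at this position. Nothing given here bears on why the number falls from one compound to the other.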